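From Phenyl to Furan-2-yl: An Expected Step

This account rests on a few compounds, and the source may have more. Where it says the series, first, only, none or still open, it means among the compounds named here.

Of the compounds shown here, three have so far been measured in a functional assay on HCT-15 cells (Homo sapiens) for cytotoxicity, read by CCK-8 assay and cell counting, with a stated time of 2 days; on this read-out lower numbers stand for stronger inhibition and higher numbers for weaker inhibition. Compound 1 `Oc1ccc(-c2cc(-c3ccccc3)nc(-c3ccccc3Cl)c2)cc1` gives 4990 nM, which places it second highest of the three numbers. Its nearest neighbour is compound 2 `Oc1cccc(-c2cc(-c3ccc(Cl)cc3)nc(-c3ccsc3)c2)c1`, whose value of 8850 nM lies within the scatter of compound 1; the furthest is compound 3 `Oc1cccc(-c2cc(-c3ccsc3)nc(-c3cccc(Cl)c3)c2)c1`, which gives 2510 nM, also within the scatter of compound 1. The only single-point step among these three is a 3.5-fold lower number from compound 2 to compound 3 (0.55 log units; beyond the scatter), a modest move that lies beyond the scatter.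

Compound 4 `Oc1ccc(-c2cc(-c3ccco3)nc(-c3ccccc3Cl)c2)cc1` differs from compound 1 in one place: furan-2-yl in place of phenyl on an aromatic carbon. Among the compounds with values here, no measured pair isolates this change. Within the data shown here, compounds 2 and 3 each differ from compound 1 in more than one place, so their values give no direct reading of it, and the single known step concerns where the chlorine sits and not the exchange made here. With nothing in the data pointing in either direction, compound 4 is expected to stay close to compound 1, a step of a 1.0-fold higher number from compound 1 to compound 4 (0.00 log units; within the scatter) that is not expected to exceed the scatter. The value of compound 4 in this assay is therefore estimated at 5000 nM, with a range from 2000 nM to 12500 nM.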

Compound 4, half-maximal inhibitory concentration: 5460 nM
Estimate against measurement, compound 4: 1.1-fold (0.04 log units) below; the range from low to high includes it.
By their numbers in this assay, from the lowest: compounds 3, 1, 4 and 2 (each within the scatter of the next, the first and the last beyond it).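

In this assay, within the data shown here, the exchange at the aromatic carbon next to the ring nitrogen gives a 1.1-fold higher number from compound 1 to compound 4 (0.04 log units; within the scatter), the first direct reading at this position, as the only earlier step concerned where the chlorine sits on a different pair of compounds. Here a phenyl group of 6 heavy atoms gives way to a furan-2-yl group of 5 heavy atoms, a five-membered aromatic ring with 1 hetero atom and 1 hydrogen-bond acceptor, and the numbers of the two compounds remain within the scatter of each other, so in the core of compound 1 this position accepts either aromatic ring without a readable difference in this assay. Nothing measured here speaks to why the two compounds lie so close.

This is a single exchange in a single setting, so the compounds shown leave open whether the same exchange would stay within the scatter in the cores of compound 2 and compound 3. They also leave open how this position would respond to a group of another kind, such as an amine, a carboxylic acid or a longer alkyl chain, in place of an aromatic ring.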